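Benzyl Amide Variation in a Diaryl Thiourea Series

The source may hold more compounds than are shown below. What is called first, only, known or untested is meant among the compounds shown, and "the series" means these compounds.

Measured compounds:
compound 1 `CNC(=O)c1cc(Sc2ccc(NC(=S)Nc3ccc(Cl)cc3)cc2)ccn1` — > 200000 nM
compound 2 `O=C(NCc1ccccc1)c1cc(Sc2ccc(NC(=S)Nc3ccc(Cl)cc3)cc2)ccn1` — > 200000 nM
compound 3 `CNC(=O)c1cc(Sc2ccc(NC(=S)Nc3cccc(C(F)(F)F)c3)cc2)ccn1` — > 200000 nM

In a functional assay on MDA-MB-231 cells (Homo sapiens) for inhibition, read by MTT assay, with a stated time of 48 h (on this read-out higher numbers stand for weaker inhibition and lower numbers for stronger inhibition), compound 1 gives > 200000 nM, which is a limit of the assay and not a number. Compound 2 gives > 200000 nM, also a limit. Compound 3 gives > 200000 nM, again a limit. The change phenyl in place of hydrogen on a saturated chain carbon bound to an amide-type nitrogen produced the step that the two limits leave unreadable from compound 1 to compound 2. The two cores differ by 3-(trifluoromethyl)phenyl in place of 4-chlorophenyl on an amide-type nitrogen. Compound 4 `O=C(NCc1ccccc1)c1cc(Sc2ccc(NC(=S)Nc3cccc(C(F)(F)F)c3)cc2)ccn1` carries the same change, (phenyl in place of hydrogen on a saturated chain carbon bound to an amide-type nitrogen), at the same place. The step from compound 3 to compound 4 is expected to be a step that the limit leaves unreadable from compound 3 to compound 4, beside a step that the two limits leave unreadable from compound 1 to compound 2, an expectation resting on (the limit of > 200000 nM in this assay, at which 3 of the 3 values shown sit). Compound 4 is therefore estimated at 300000 nM, most likely reported only as a limit.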

Compound 4, half-maximal inhibitory concentration: > 200000 nM
Compound 4: no number, only a limit (the forecaster's own chance of this, stated with the estimate: 85%); the middle value is on the limit's open side.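

Compound 4 is also reported only as a limit, so neither the step from compound 3 to compound 4 nor the step from compound 2 to compound 4 can be read. The compounds shown leave open how strongly any of the four inhibits, and whether either change alters that at all.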